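A few compounds are considered here, and "the series" means these few. Any claim that something is new, unique, unknown or untested is made for them only; others in the source may bear on it.

In an assay on BaF3 cells for inhibition of proto-oncogene tyrosine-protein kinase receptor Ret (Homo sapiens), read by MTT assay, with a stated time of 48 h (on this read-out lower numbers stand for stronger inhibition of growth and higher numbers for weaker inhibition of growth), three compounds of a shared core have been measured. Compound 1 `CC(C)(O)Cn1nc(-c2cc(C3CC3)on2)c2c(N)ncnc21` gives 1770 nM, compound 2 `CC(C)n1nc(/C=N/OCc2ccccc2)c2c(N)ncnc21` gives 7410 nM, and compound 3 `CC(C)n1nc(-c2cc(-c3ccccc3)on2)c2c(N)ncnc21` gives 3460 nM. Compound 3 therefore holds the second highest of the three numbers: it lies within the scatter of compound 1, while compound 2 sits beyond the scatter on the higher side. Compound 4 `CCc1cc(-c2nn(C(C)C)c3ncnc(N)c23)no1` differs from compound 3 by ethyl in place of phenyl on an aromatic carbon. Among the measured compounds shown here, no measured pair shows this exchange. For the measured compounds named here, the only other compound carrying the same five-membered aromatic ring, compound 1, gives 1770 nM, within the scatter of compound 3, so the step of a 1.2-fold lower number from compound 3 to compound 4 (0.09 log units; within the scatter) is expected to stay small, if anything slightly downward. Compound 4 is estimated at 2800 nM, with a range from 1000 nM to 8000 nM.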

Compound 4, concentration for 50% growth inhibition: 1560 nM
Estimate against measurement, compound 4: 1.8-fold (0.25 log units) above, within the range that was stated.
By their numbers in this assay, from the lowest: compounds 4, 1 and 3 (each within the scatter of the next, the first and the last beyond it); then compound 2.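

In this assay, among the compounds shown here, ethyl in place of phenyl, on the aromatic carbon next to the ring oxygen, gives a 2.2-fold lower number from compound 3 to compound 4 (0.35 log units; beyond the scatter) as the first step that can be read at this position. The six-membered aromatic ring is thus not needed here to keep the number low, and the smaller group without a ring reads lower. Nothing available explains this step.

The compounds shown leave open whether methyl or a longer chain such as butyl on this carbon would move the number further. They also leave open how an amine would read there.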